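Piperazine aryl variation in a T-type calcium channel series

The source may hold more compounds than are shown below. What is called first, only, known or untested is meant among the compounds shown, and "the series" means these compounds.

Compound 1 `CCCc1nc(-c2ccccc2)c(CNCCN2CCN(c3ccc(C)cc3)CC2)o1` gives 48.1% in an assay on HEK293 cells for inhibition of Voltage-dependent T-type calcium channel subunit alpha-1G (Homo sapiens), read by fluorescence, tested at 10 uM; a lower number here means less inhibition, a higher number more inhibition at the concentration tested (going by the name of the read-out).
Compound 2 `CCCc1nc(-c2ccccc2)c(CNCCN2CCN(c3cccc(C)c3C)CC2)o1` gives 66.7% in this assay.
Compound 3 `CCCc1nc(-c2ccccc2)c(CNCCN2CCN(c3ccccc3C(F)(F)F)CC2)o1` gives 54.6% in this assay.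

Compound 3 stands second highest of the three: compound 1 is nearest, a number 6.5 percentage points higher from compound 1 to compound 3 (within the scatter), and compound 2 furthest, a number 12.1 percentage points lower from compound 2 to compound 3 (beyond the scatter). Compound 4 `CCCc1nc(-c2ccccc2)c(CNCCN2CCN(c3ccc(F)cc3)CC2)o1` differs from compound 3 in one place: 4-fluorophenyl in place of 2-(trifluoromethyl)phenyl on an amine nitrogen in a ring. The measured steps that bear on this all change the same aryl group on the ring nitrogen; the move to 4-methylphenyl, a number 6.5 percentage points higher from compound 1 to compound 3 (within the scatter), stayed within the scatter, while a number 18.6 percentage points higher from compound 1 to compound 2 (beyond the scatter) was a modest rise. Since the new group is again substituted as 4-methylphenyl is, compound 4 is expected to land close to compound 1, meaning an estimated a number 6.6 percentage points lower from compound 3 to compound 4 (within the scatter). For compound 4 the estimate in this assay is 48%, between 33% and 63%.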

Compound 4, a percentage reported as inhibition, at one concentration (the size of the read-out at that concentration, not a potency): 54.1%
Beside the measured number, compound 4's estimate is 6.1 percentage points below it; the measured number falls inside the stated range.
By their numbers in this assay, from the lowest: compounds 1, 4 and 3 (each within the scatter of the next); then compound 2.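

In this assay, the new compound shows that a single fluoro group on the phenyl ring can stand in for the larger 2-(trifluoromethyl)phenyl group without a readable change, a number 0.5 percentage points lower from compound 3 to compound 4 (within the scatter), and fluoro in place of methyl gives the same picture, a number 6 percentage points higher from compound 1 to compound 4 (within the scatter). Only the 2,3-dimethylphenyl group of compound 2 stands apart, now against a third aryl group, a number 12.6 percentage points lower from compound 2 to compound 4 (beyond the scatter). Nothing measured here accounts for that gap.

Going by these compounds, what an amine or a carboxylic acid on this phenyl ring would do remains open, as does a pyridine ring in its place.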